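This account rests on a few compounds, and the source may have more. Where it says the series, first, only, none or still open, it means among the compounds named here.

Measured so far in an ADME assay on Vero cells (Chlorocebus sabaeus) for cytotoxicity, read by sulforhodamine B assay, with a stated time of 3 days; on this read-out higher numbers stand for lower toxicity in this test and lower numbers for higher toxicity in this test:
Compound 1 `CC1=C(C(=O)Nc2ccc(Cl)cc2)C(c2ccco2)C(C(=O)Nc2ccc(Cl)cc2)=C(C)N1`: 24 ug/mL
Compound 2 `COc1cc(C2C(C(=O)Nc3ccc(Cl)cc3)=C(C)NC(C)=C2C(=O)Nc2ccc(Cl)cc2)ccc1O`: 250 ug/mL

Compound 1 stands lowest of these two numbers, so it is the more toxic of the pair in this assay. Compound 3 `CC1=C(C(=O)Nc2ccc(Cl)cc2)C(c2cccc(Cl)c2)C(C(=O)Nc2ccc(Cl)cc2)=C(C)N1` keeps the core of compound 1 and carries 3-chlorophenyl in place of furan-2-yl on a saturated ring carbon. Going by the values given here, only one measured step bears on this change, and it leaves the same furan-2-yl. It brings in 4-hydroxy-3-methoxyphenyl and is large: a 10-fold higher number from compound 1 to compound 2 (1.02 log units; beyond the scatter). The entering group here is a different phenyl, and one step cannot show how much of that rise would carry over. A step in the same direction is therefore expected, but a smaller one. The expected step is a 1.9-fold higher number from compound 1 to compound 3 (0.27 log units; within the scatter). For compound 3 the estimated value is 45 ug/mL, with an expected range of 13 ug/mL to 160 ug/mL.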

Compound 3, half-maximal cytotoxic concentration: 12 ug/mL
Compound 3: the middle estimate sits 3.8-fold (0.57 log units) above what was measured; the measured number lies below the stated range.
By their numbers in this assay, from the lowest: compounds 3 and 1 (each within the scatter of the next); then compound 2.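

In this assay, the rise seen with 4-hydroxy-3-methoxyphenyl does not extend to every phenyl on this saturated ring carbon: 3-chlorophenyl in place of furan-2-yl gives a step within the scatter (a 2.0-fold lower number from compound 1 to compound 3 (0.30 log units; within the scatter)). Exchanging the phenyl substituents at the same place gives a large step beyond the scatter (a 21-fold lower number from compound 2 to compound 3 (1.32 log units; beyond the scatter)), so a phenyl group alone does not bring the high number of compound 2, and what it carries matters here. No measurement available gives a reason for this gap.

The compounds shown leave open whether the hydroxy or the methoxy of compound 2 goes with its high number. They also leave open how a phenyl bearing an amine or a carboxylic acid would read at this position.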